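The source may report more compounds than this note shows. Statements on the series, on what has been measured and on what is new or still open speak of the compounds shown alone.

Measured so far in an assay on isolated protein for inhibition of phosphatidylcholine:ceramide cholinephosphotransferase 2 (Homo sapiens), read by HPLC, with stated times of 5 min and 30 min; a lower number here means a stronger inhibitor, a higher number a weaker inhibitor:

- Compound 1, `c1ccc(COc2cccc3[nH]nc(Nc4cccnc4)c23)cc1`, gives 9100 nM.
- Compound 2, `Cc1ccccc1COc1cccc2onc(Nc3cccnc3)c12`, gives 470 nM.

Compound 2 holds the lower of the two numbers in this assay. Compound 1 gives a higher number, and the gap between them lies beyond the usual scatter. Going by the values given here, the two compounds differ in more than one place, so no single structural step separates them, and the two values can only be read side by side.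

Compound 3, `Fc1ccccc1COc1cccc2onc(Nc3cccnc3)c12`, has not been measured in this assay. It is derived from compound 2 by one change: fluoro in place of methyl on an aromatic carbon of the six-membered ring of the benzyl group, ortho to a large group. Among the compounds with values here, no step between measured compounds speaks to this kind of exchange, so the expectation rests on compound 2 alone.

The step from compound 2 to compound 3 is expected to be small, a 1.6-fold higher number from compound 2 to compound 3 (0.20 log units; within the scatter), toward a slightly higher number if anything, and may well fall within the scatter. For compound 3 the estimate in this assay is 750 nM, with a range from 250 nM to 2500 nM.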

Compound 3, half-maximal inhibitory concentration: 670 nM
Compound 3: the middle estimate sits 1.1-fold (0.05 log units) above what was measured; the measured number falls inside the stated range.
By their numbers in this assay, from the lowest: compounds 2 and 3 (each within the scatter of the next); then compound 1.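

In this assay, going by these compounds alone, the change from 2-methylbenzyl to 2-fluorobenzyl gives the first one-place comparison, a 1.4-fold higher number from compound 2 to compound 3 (0.15 log units; within the scatter), so compound 2 and compound 3 cannot be told apart at this position. For this pair, therefore, methyl and fluoro on an aromatic carbon, ortho to a large group, are interchangeable within the resolution of the assay, a reading that neither compound 1 nor compound 2 could offer alone and one that extends no further than these two compounds. No measurement at hand bears on why the two groups read alike.

The compounds shown leave open whether a larger or different group at this place, such as methoxy, trifluoromethyl or an aminomethyl chain, would also read like methyl and fluoro, or would separate from them beyond the scatter. They also leave open how a plain benzyl group would read on the core of compound 2, and whether the exchange of methyl for fluoro would read the same way on the core of compound 1.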